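The compounds below may be only part of what the source reports. "The series", "measured", "known", "first", "only" and "open" are said of these compounds alone.

Working notes on the series. Two compounds share one core: compound 1, `COc1ccc(CNC(=O)c2cccn2-c2ccc3c(c2)B(O)OC3)cc1`, and compound 2, `O=C(c1ccc(F)cc1)c1ccn(-c2ccc3c(c2)B(O)OC3)c1`. In an ADME assay on L929 cells (Mus musculus) for cytotoxicity, read by resazurin assay, with a stated time of 72 h (a higher number here means a weaker inhibitor, a lower number a stronger inhibitor), compound 1 gives > 10 ug/mL, which is a limit of the assay and not a number. In this assay compound 2 gives > 10 ug/mL, again a limit rather than a number. Within the data shown here, compound 2 thus stands at the limit of > 10 ug/mL in this assay, at which 2 of the 2 values shown sit, and with two limits no step between measured compounds can be drawn. Compound 3, `O=C(c1ccc(O)cc1)c1ccn(-c2ccc3c(c2)B(O)OC3)c1`, is not yet measured. It differs from compound 2 by hydroxy in place of fluoro on an aromatic carbon. Among the measured compounds shown here, no measured step covers this change, so in this assay no shift beyond the scatter is expected, and compound 3 is expected to remain at the limit. For compound 3 the estimate in this assay is 15 ug/mL, with a range from 7 ug/mL to 40 ug/mL. The step this estimate means is expected to be a step that the limit leaves unreadable from compound 2 to compound 3.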

Compound 3, half-maximal inhibitory concentration: > 10 ug/mL
Compound 3: only a limit was reported; the forecaster's own chance of this, stated with the estimate: 80%; the middle value does not contradict the limit.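

Compound 2 and compound 3 both stand at a limit and not a number in this assay, so no step between them can be read: the limit of > 10 ug/mL in this assay, at which 3 of the 3 values shown sit.

The compounds shown leave open where any of them would give a number in this assay, and what hydroxy in place of fluoro changes there.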